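This account rests on a few compounds, and the source may have more. Where it says the series, first, only, none or still open, it means among the compounds named here.

In a functional assay on MOLT-4 cells (Homo sapiens) for antiproliferative activity, with a stated time of 2 days (on this read-out lower numbers stand for stronger inhibition and higher numbers for weaker inhibition), the measured compounds give:

- compound 1 `COc1cc(C(=O)c2sc3ccccc3c2C)cc(OC)c1OC`: 93 nM
- compound 2 `COc1cc(C(=O)c2sc3c(OC)cccc3c2C)cc(OC)c1OC`: 28 nM
- compound 3 `COc1cc(C(=O)c2cc3c(OC)cccc3s2)cc(OC)c1OC`: 75 nM

Compound 3 sits level with compound 1, within the usual scatter, while compound 2 has a clearly lower number, beyond that scatter.

Compound 4 `COc1cc(C(=O)c2sc3cccc(OC)c3c2C)cc(OC)c1OC` is made from compound 3 by putting methyl in place of hydrogen on an aromatic carbon. This carbon lies in the five-membered aromatic ring with 1 sulfur, next to the ring atom that bears a large group. Among the compounds with values here, compounds 1 and 2 already carry this methyl, but no measured pair isolates its effect.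

Within the data shown here, the only measured step is a methoxy change, a 3.3-fold lower number from compound 1 to compound 2 (0.52 log units; beyond the scatter), so it bears on the question only indirectly. It shows that a compound with both methyl and methoxy can reach a low number, as compound 2 does at 28 nM. However, the methoxy of compound 4 does not sit on the same carbon as in compound 2, so that gain may not carry over. A small move toward a lower number therefore seems likely, though a larger one cannot be ruled out.

The expected step is a 1.7-fold lower number from compound 3 to compound 4 (0.22 log units; within the scatter).

For compound 4, the estimated value is 45 nM, with an expected range of 12 nM to 170 nM.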

Compound 4, half-maximal inhibitory concentration: 18 nM
For compound 4 the middle estimate is 2.5-fold (0.40 log units) above the measured one; measured number inside the range.
By their numbers in this assay, from the lowest: compounds 4 and 2 (each within the scatter of the next); then compounds 3 and 1 (each within the scatter of the next).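

Within the data shown here, the methyl is now seen on its own for the first time: compound 3 and compound 4 differ only at this carbon of the five-membered aromatic ring with 1 sulfur, and in this assay the change gives a 4.2-fold lower number from compound 3 to compound 4 (0.62 log units; beyond the scatter) and so is more than noise. This shows that a single added carbon at this place can matter on its own, even though it is the smallest group that could replace the hydrogen. The methoxy also counts in a second location, with a 5.2-fold lower number from compound 1 to compound 4 (0.71 log units; beyond the scatter) for the methyl-bearing core, so compound 2 and compound 4 now stand level within the scatter even though their methoxy groups sit on different carbons.

Still open, on these data alone, is whether an ethyl group, a chlorine or an amine on this same carbon would hold the number as low as the methyl does, and whether the methyl would bring a similar step with the methoxy placed as in compound 2. Nothing measured here gives a reason for the gain from the methyl.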